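From 2-chlorobenzyl to 2,4-dichlorobenzyl in compound 4

This account rests on a few compounds, and the source may have more. Where it says the series, first, only, none or still open, it means among the compounds named here.

Compound 1 `O=[N+]([O-])c1cc(C(F)(F)F)cc([N+](=O)[O-])c1Oc1c(Cl)cc(Cl)cc1/C=N\OCc1ccccc1` gives 1120 nM
Compound 2 `O=[N+]([O-])c1cc(C(F)(F)F)cc([N+](=O)[O-])c1Oc1c(Cl)cc(Cl)cc1/C=N\OCc1ccccc1F` gives 820 nM
Compound 3 `O=[N+]([O-])c1cc(C(F)(F)F)cc([N+](=O)[O-])c1Oc1c(Cl)cc(Cl)cc1/C=N/OCc1ccccc1Cl` gives 1120 nM

These values come from a functional assay on HepG2 cells (Homo sapiens) for antiproliferative activity, read by MTT assay, with a stated time of 48 h (a higher number here means a weaker inhibitor, a lower number a stronger inhibitor), and all lie within the usual scatter of one another. Compound 1 and compound 3 read alike (1120 nM). Compared with compound 3, compound 4 `O=[N+]([O-])c1cc(C(F)(F)F)cc([N+](=O)[O-])c1Oc1c(Cl)cc(Cl)cc1/C=N/OCc1ccc(Cl)cc1Cl` swaps 2-chlorobenzyl for 2,4-dichlorobenzyl, with chloro in place of hydrogen on an aromatic carbon. The closest measured steps also add a halogen to the benzyl group, showing no change at the digits printed from compound 1 to compound 3 (within the scatter) and a 1.4-fold lower number from compound 1 to compound 2 (0.14 log units; within the scatter) as their whole effect. Among the measured compounds shown here, no measured step adds a second chloro. No shift beyond the scatter is therefore expected in this assay, and the expected step is small (a 1.1-fold lower number from compound 3 to compound 4 (0.05 log units; within the scatter)). For compound 4 the estimated value is 1000 nM with an expected range from 450 nM to 2200 nM in this measurement.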

Compound 4, half-maximal inhibitory concentration: 940 nM
Estimate against measurement, compound 4: 1.1-fold (0.03 log units) above; the range from low to high includes it.
By their numbers in this assay, from the lowest: compounds 2, 4, 1 and 3 (each within the scatter of the next).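

In this assay, a second chloro on the benzyl ring, para to a large group and meta to a chloro group, stays within the scatter (a 1.2-fold lower number from compound 3 to compound 4 (0.08 log units; within the scatter)). The same holds against the benzyl ring without halogen (a 1.2-fold lower number from compound 1 to compound 4 (0.08 log units; within the scatter)) and against the ring with one fluoro (a 1.1-fold higher number from compound 2 to compound 4 (0.06 log units; within the scatter)), so this ring now carries two halogens with no shift beyond the scatter. Nothing available explains this result. Still open, as far as these compounds go, is how an amine, a carboxylic acid or a longer chain at this place would read in this assay.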